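Chloro to methoxy: a swap with little data behind it

The compounds below may be only part of what the source reports. "The series", "measured", "known", "first", "only" and "open" are said of these compounds alone.

In a functional assay on HepG2 cells (Homo sapiens) for inhibition, read by MTT assay, with a stated time of 48 h (a higher number here means a weaker inhibitor, a lower number a stronger inhibitor), compound 1 `COc1ccc(-c2nc3c(c(-c4ccccc4)nn3-c3ccccc3)c(-c3ccc(N4CCCCC4)cc3)c2C#N)cc1` gives 12500 nM and compound 2 `CN1CCN(c2ccc(-c3c(C#N)c(-c4ccc(Cl)cc4)nc4c3c(-c3ccccc3)nn4-c3ccccc3)cc2)CC1` gives 14600 nM. These two values lie within the usual scatter of repeated measurements, so neither compound can be ranked above the other.

Compound 3 `COc1ccc(-c2nc3c(c(-c4ccccc4)nn3-c3ccccc3)c(-c3ccc(N4CCN(C)CC4)cc3)c2C#N)cc1` comes from compound 2 through a single change: methoxy in place of chloro on an aromatic carbon. This places methoxy in place of chloro on an aromatic carbon, turning 4-chlorophenyl into 4-methoxyphenyl. For the measured compounds named here, no measured pair differs by this change alone, so the data give no direct guide to its size. Going by the values given here, the only evidence is how close compound 1 at 12500 nM and compound 2 at 14600 nM sit, so no shift beyond the scatter is expected in this assay, in either direction. The estimated step is a 1.1-fold lower number from compound 2 to compound 3 (0.05 log units; within the scatter), which stays within the scatter. Compound 3 is expected at 13000 nM, with an estimated range of 6000 nM to 26000 nM.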

Compound 3, half-maximal inhibitory concentration: 1330 nM
Compound 3: middle estimate off by 9.8-fold (0.99 log units), on the high side, and the stated range ends above it.
By their numbers in this assay, from the lowest: compound 3; then compounds 1 and 2 (each within the scatter of the next).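

In this assay, this position on the aromatic ring is far from silent: with 4-methylpiperazin-1-yl held in place, going from 4-chlorophenyl to 4-methoxyphenyl gives an 11-fold lower number from compound 2 to compound 3 (1.04 log units; beyond the scatter). The other end of the molecule matters too, since with 4-methoxyphenyl held in place, 4-methylpiperazin-1-yl in place of piperidin-1-yl gives a 9.4-fold lower number from compound 1 to compound 3 (0.97 log units; beyond the scatter). Compounds 1 and 2 differ in both places, so their closeness concealed that each single change can matter, and nothing available explains why either one does.

The compounds shown cannot tell whether the gain from methoxy depends on 4-methylpiperazin-1-yl being present, or whether it would also appear with piperidin-1-yl. They also leave open how other groups at this position would behave, such as hydroxy, ethoxy or a primary amine.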